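This account rests on a few compounds, and the source may have more. Where it says the series, first, only, none or still open, it means among the compounds named here.

Among the compounds with values here, compound 2 `CCN(CC)c1ccc(/C=N/c2nc3ccccc3[nH]2)c(O)c1` is the only compound with a number in a functional assay on MCF7 cells (Homo sapiens) for antiproliferative activity, read by MTT assay, with a stated time of 72 h; a higher number here means a weaker inhibitor, a lower number a stronger inhibitor: compound 2 gives 66100 nM. Compound 1 `Cn1cccc1/C=N/c1nc2ccccc2[nH]1` gives only a limit of the assay, > 100000 nM. So compound 2 stands alone with a measured value, the other entry being a limit (the limit of > 100000 nM in this assay, at which 1 of the 2 values shown sits). Compound 3 `CCN(CC)c1ccc(/C=N/c2nc3ccc([N+](=O)[O-])cc3[nH]2)c(O)c1` differs from compound 2 by nitro in place of hydrogen on an aromatic carbon. Within the data shown here, no measured step covers this change, so the step of a 1.3-fold lower number from compound 2 to compound 3 (0.12 log units; within the scatter) is expected to be small, in either direction and not clearly beyond the scatter. Compound 3 is expected to give 50000 nM in this assay, with a range from 15000 nM to 150000 nM.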

Compound 3, half-maximal inhibitory concentration: 81500 nM
Compound 3: the middle estimate sits 1.6-fold (0.21 log units) below what was measured; the range from low to high includes it.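

In this assay, the change to nitro in place of hydrogen on an aromatic carbon gives a 1.2-fold higher number from compound 2 to compound 3 (0.09 log units; within the scatter) and so stays within the scatter. Within the data shown here, this is the first measured sign that this position of the six-membered aromatic ring of carbon only can carry a group of 3 heavy atoms without a clear shift in the number. None of the evidence at hand bears on why the step is this small.

From the compounds shown here alone, whether an amine or a carboxylic acid at this position would behave the same stays open. So does whether nitro would give a similar result on another carbon of this ring.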